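Amino for methyl on a short-lived compound

The compounds below may be only part of what the source reports. "The series", "measured", "known", "first", "only" and "open" are said of these compounds alone.

In an ADME assay on the whole organism (strain Sprague-Dawley) for metabolic stability, with Rattus norvegicus as the target (a higher number here means that the compound lasts longer, a lower number that the compound disappears faster), compound 1 `Nc1nc2c(s1)CC[C@H]2C(=O)Nc1ccc(C[C@@H]2CC[C@H]([C@H](O)c3ccccc3)N2)cc1` gives 4 h, while compound 2 `Cc1nc2c(s1)CC[C@H]2C(=O)Nc1ccc(C[C@@H]2CC[C@H]([C@H](O)c3cccnc3)N2)cc1` gives 1 h, the lower of the two numbers and beyond the scatter. Compound 3 `Nc1nc2c(s1)CC[C@H]2C(=O)Nc1ccc(C[C@@H]2CC[C@H]([C@H](O)c3cccnc3)N2)cc1` differs from compound 2 in one place: amino in place of methyl on an aromatic carbon. For the measured compounds named here, no single-change step has been measured in this assay. Compound 1 also carries amino on that carbon and gives 4 h, so a modest rise is expected for compound 3. The expected change is a 2.0-fold higher number from compound 2 to compound 3 (0.30 log units; within the scatter), about the size of the scatter. For compound 3 the estimated half-life is 2 h, with a range of 1 h to 4 h.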

Compound 3, half-life: 4 h
The estimate for compound 3 lay 2.0-fold (0.30 log units) below the measured number, within the range that was stated.
By their numbers in this assay, from the lowest: compound 2; then compounds 1 and 3 (each within the scatter of the next).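

In this assay, amino in place of methyl on the aromatic carbon next to the ring nitrogen and next to the ring sulfur gives a 4.0-fold higher number from compound 2 to compound 3 (0.60 log units; beyond the scatter) as a single change at this position. With amino on that carbon, pyridin-3-yl in place of phenyl gives no change at the digits printed from compound 1 to compound 3 (within the scatter) on the saturated chain carbon. No measurement given here explains either step.

From the compounds shown here alone, whether a methylamino group or a bare hydrogen on that carbon would match amino remains open. So does whether methyl with phenyl would behave as methyl does with pyridin-3-yl.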